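This account rests on a few compounds, and the source may have more. Where it says the series, first, only, none or still open, it means among the compounds named here.

Measured so far, in a functional assay on A-375 cells (Homo sapiens) for antiproliferative activity, read by CCK-8 assay, with a stated time of 72 h, tested at 2 uM; a lower number here means a weaker effect, a higher number a stronger effect of the compound at the concentration tested:

Compound 1, `Nc1ccccc1NC(=O)c1ccc(CSC(=S)N2CCN(c3ccccc3)CC2)cc1`: 27.5%
Compound 2, `CC1CCN(C(=S)SCc2ccc(C(=O)Nc3ccccc3N)cc2)CC1`: 32.7%
Compound 3, `CN(Cc1ccncc1)C(=S)SCc1ccc(C(=O)Nc2ccccc2N)cc1`: 31.4%

Compound 1 gives the lowest of the three numbers, but the gaps to compound 3 and to compound 2 both lie within the scatter of the measurement, so the three compounds cannot be told apart on these numbers. The unmeasured compound 4, `Nc1ccccc1NC(=O)c1ccc(CSC(=S)N2CCN(c3ccncc3)CC2)cc1`, differs from compound 1 in one place: pyridin-4-yl in place of phenyl on an amine nitrogen in a ring. For the measured compounds named here, only one measured step bears on this, and indirectly: the change a number 1.3 percentage points lower from compound 2 to compound 3 (within the scatter) also brings a pyridin-4-yl group into the part of the molecule attached to the thiocarbonyl carbon, and it left the number essentially unchanged. Nothing among the three compounds suggests that a pyridine nitrogen in this part shifts the read-out. The step of a number 1.5 percentage points higher from compound 1 to compound 4 (within the scatter) is therefore expected to stay within the scatter. Compound 4 is estimated to give 29%, with a plausible range from 18% to 42%.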

Compound 4, a percentage reported as inhibition, at one concentration (the size of the read-out at that concentration, not a potency): 85.7%
For compound 4 the middle estimate is 56.7 percentage points below the measured one; measured number outside the range, above it.
By their numbers in this assay, from the lowest: compounds 1, 3 and 2 (each within the scatter of the next); then compound 4.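

In this assay, exchanging phenyl for pyridin-4-yl on the amine nitrogen in the ring gives a number 58.2 percentage points higher from compound 1 to compound 4 (beyond the scatter), so this position responds strongly to a small change: both groups have the same number of heavy atoms, but the entering ring holds one nitrogen and one hydrogen-bond acceptor. A pyridin-4-yl group does not bring such a rise wherever it appears, since the change elsewhere in the series gave only a number 1.3 percentage points lower from compound 2 to compound 3 (within the scatter), so the gain belongs to this particular setting. Nothing available explains the large rise.

The compounds shown leave open whether the ring nitrogen must sit where it does in pyridin-4-yl, which a pyridin-3-yl or pyridin-2-yl group on the same amine nitrogen would test. A pyrimidin-5-yl ring there would show whether a second ring nitrogen keeps, adds to or loses the gain.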